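From compound 3 to compound 4: little change expected

This account rests on a few compounds, and the source may have more. Where it says the series, first, only, none or still open, it means among the compounds named here.

In a functional assay on MCF7 cells (Homo sapiens) for antiproliferative activity, read by MTT assay (on this read-out higher numbers stand for weaker inhibition and lower numbers for stronger inhibition), compound 1 `COc1cc2c(Oc3ccc(NC(=O)Nc4cccc(C)c4)cc3)ccnc2cc1OCCCCCCC(=O)NO` gives 1240 nM while compound 2 `COc1cc2c(Oc3ccc(NC(=O)Nc4ccccc4F)cc3)ccnc2cc1OCCCCCCC(=O)NO` gives 660 nM and compound 3 `COc1cc2c(Oc3ccc(NC(=O)N/N=C/c4ccccc4)cc3)ccnc2cc1OCCCCCCC(=O)NO` gives 610 nM on the shared core. Compound 3 sits level with compound 2 and modestly apart from compound 1, as a 1.1-fold lower number from compound 2 to compound 3 (0.03 log units; within the scatter) and a 2.0-fold lower number from compound 1 to compound 3 (0.31 log units; beyond the scatter) show. Within the data shown here, the change to compound 4 `COc1cc2c(Oc3ccc(NC(=O)NNC(=O)c4ccccc4F)cc3)ccnc2cc1OCCCCCCC(=O)NO` is a group of 10 heavy atoms (7 carbon, 1 nitrogen, 1 oxygen, 1 fluorine; one six-membered aromatic ring of carbon only) in place of a group of 8 heavy atoms (7 carbon, 1 nitrogen; one six-membered aromatic ring of carbon only), on an amide-type nitrogen and no measured step tests it directly. The third measured step at this nitrogen, a 1.9-fold lower number from compound 1 to compound 2 (0.27 log units; within the scatter) is equally small, so no shift beyond the scatter is expected in this assay here. The expected move is a 1.3-fold higher number from compound 3 to compound 4 (0.12 log units; within the scatter) and nothing more. Compound 4 is estimated at 800 nM with a range from 350 nM to 1800 nM as the expected span.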

Compound 4, half-maximal inhibitory concentration: 3600 nM
Estimate against measurement, compound 4: 4.5-fold (0.65 log units) below; the whole stated range lies below it.
By their numbers in this assay, from the lowest: compounds 3, 2 and 1 (each within the scatter of the next, the first and the last beyond it); then compound 4.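

In this assay, ((2-fluorophenyl)carbonyl)amino on the amide-type nitrogen gives the first rise beyond the scatter at this position, whichever earlier group it replaces (a 5.9-fold higher number from compound 3 to compound 4 (0.77 log units; beyond the scatter); a 5.5-fold higher number from compound 2 to compound 4 (0.74 log units; beyond the scatter); a 2.9-fold higher number from compound 1 to compound 4 (0.46 log units; beyond the scatter)). The number at this position therefore depends on the group attached, and the earlier compounds had shown no change of this direction or size. Nothing available explains the rise. The compounds shown leave open whether the rise follows the carbonyl or the fluorine on the ring. They also leave open how a benzylamine or a carboxylic acid on this nitrogen would read.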